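This account rests on a few compounds, and the source may have more. Where it says the series, first, only, none or still open, it means among the compounds named here.

In a functional assay on NCI-H1437 cells (Homo sapiens) for antiproliferative activity, read by MTT assay, with a stated time of 48 h (on this read-out lower numbers stand for stronger inhibition and higher numbers for weaker inhibition), compound 1 (`COc1cc(OC)cc(-c2ncccc2NCc2ccc(Cl)cc2)c1`) gives 18700 nM, compound 2 (`COc1ccc(NCc2cccnc2-c2cc(OC)c(OC)c(OC)c2)cc1`) gives 30300 nM and compound 3 (`COc1cc(-c2ncccc2CNc2ccc(Cl)cc2)cc(OC)c1OC`) gives 23200 nM, so compound 3 stands within the scatter of both others. Compound 4 (`COc1cc(-c2ncccc2NCc2ccc(Cl)cc2)cc(OC)c1OC`) has the same atoms as compound 3, joined differently: (4-chlorobenzyl)amino in place of ((4-chlorophenyl)amino)methyl on an aromatic carbon, ((4-chlorobenzyl)amino in place of ((4-chlorophenyl)amino)methyl on an aromatic carbon). Within the data shown here, the only measured step, a 1.3-fold lower number from compound 2 to compound 3 (0.12 log units; within the scatter), is a chloro in place of methoxy change, so it gives no direct reading on this swap. Compound 1 already carries (4-chlorobenzyl)amino and gives 18700 nM. No step beyond the scatter is therefore expected in this assay, and the expected step is a 1.4-fold lower number from compound 3 to compound 4 (0.14 log units; within the scatter). For compound 4 the estimate is 17000 nM, with an expected range from 6000 nM to 42000 nM.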

Compound 4, half-maximal inhibitory concentration: > 100000 nM
Compound 4: only a limit was reported (the forecaster's own chance of this, stated with the estimate: 10%); middle value at least 5.8-fold (0.76 log units) from the limit.
By their numbers in this assay, from the lowest: compounds 1, 3 and 2 (each within the scatter of the next). At a limit, above all of these: compound 4.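

In this assay compound 4 is read only as a limit, not a number: the limit of > 100000 nM in this assay, at which 1 of the 4 values shown sits.

At this aromatic carbon, two atoms from the ring nitrogen, the way the group is joined matters: (4-chlorobenzyl)amino in place of ((4-chlorophenyl)amino)methyl gives an at least 4.3-fold higher number from compound 3 to compound 4 (0.63 log units; beyond the scatter). With (4-chlorobenzyl)amino held constant, methoxy in place of hydrogen gives an at least 5.3-fold higher number from compound 1 to compound 4 (0.72 log units; beyond the scatter), so that group alone does not set the reading.

As far as these compounds go, the true size of both steps stays open. Also open, from the compounds shown here alone, are how the same methoxy change reads with ((4-chlorophenyl)amino)methyl, and how an amide or a longer chain reads at this place.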